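Trifluoromethoxy to ethoxy: clearance of compound 3

The source may hold more compounds than are shown below. What is called first, only, known or untested is meant among the compounds shown, and "the series" means these compounds.

Compound 2 `O=C(O)Cn1nc(Cc2nc3cc(Cl)c(OC(F)(F)F)cc3[nH]2)c2ccccc2c1=O` reads < 81.7 mL/min/kg in an ADME assay on microsomes from liver (Mus musculus) for metabolic stability (on this read-out higher numbers stand for fast clearance and lower numbers for slow clearance), and this is a limit of the assay, not a number. Among the measured compounds shown here, compound 1 `CCOc1cc2[nH]c(Cc3nn(CC(=O)N4CCOCC4)c(=O)c4ccccc34)nc2cc1Cl` gives 817 mL/min/kg in this assay as the only exact value so far. Compound 3 `CCOc1cc2[nH]c(Cc3nn(CC(=O)O)c(=O)c4ccccc34)nc2cc1Cl` carries ethyl in place of trifluoromethyl on an oxygen on an aromatic ring. For the measured compounds named here, no measured step covers this change, so only a modest rise in this assay is expected, possibly no larger than the scatter. The estimated step of an at least 1.1-fold higher number from compound 2 to compound 3 (0.04 log units; that floor lies within the scatter) is correspondingly small. Compound 3 is estimated at 90 mL/min/kg in this assay, with an expected range of 40 mL/min/kg to 250 mL/min/kg for this value.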

Compound 3, clearance: < 51.7 mL/min/kg
Compound 3 ended at the assay's limit; the forecaster's own chance of this, stated with the estimate: 45%; middle value at least 1.7-fold (0.24 log units) away from the limit.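

In this assay compound 3 reads < 51.7 mL/min/kg, which is a limit of the assay. Compound 2 also reads as a limit, so the change from trifluoromethoxy to ethoxy cannot be read between these two compounds. With ethoxy held fixed, hydroxy in place of morpholin-4-yl on a carbonyl carbon gives an at least 15-fold lower number from compound 1 to compound 3 (1.19 log units; beyond the scatter).

As far as these compounds go, how far compound 2 and compound 3 lie under their limits remains open. Also open, from the compounds shown here alone, is how trifluoromethoxy behaves with the morpholin-4-yl amide, and whether a methyl ester or a simple dimethylamide on that carbonyl carbon reads like compound 1 or compound 3.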